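This account rests on a few compounds, and the source may have more. Where it says the series, first, only, none or still open, it means among the compounds named here.

Of the compounds shown here, three from one series have been tested so far. Compound 1 `O=C1/C(=C/c2ccccc2F)CN(C(=S)SCc2cn(Cc3ccccc3Cl)nn2)C/C1=C\c1ccccc1F`, compound 2 `Cc1ccc(/C=C2\CN(C(=S)SCc3cn(Cc4ccccc4F)nn3)C/C(=C\c3ccc(C)cc3)C2=O)cc1` and compound 3 `O=C1/C(=C/c2ccccc2F)CN(C(=S)SCc2cn(Cc3ccccc3F)nn2)C/C1=C\c1ccccc1F` share a core built around a central ketone flanked by two aryl methylidene arms, with a thiocarbamate-type linker leading to a triazole that carries a substituted benzyl group. In a functional assay on MDA-MB-231 cells (Homo sapiens) for cytotoxicity, read by MTT assay, with a stated time of 24 h (a higher number here means a weaker inhibitor, a lower number a stronger inhibitor), compound 3 gives 57600 nM, and compound 1 gives 100000 nM. The step of a 1.7-fold higher number from compound 3 to compound 1 (0.24 log units; within the scatter) comes from a single change, (chloro in place of fluoro on an aromatic carbon), placed ortho to a large group on the benzyl ring. In this assay compound 2 gives 91500 nM; its numbers sit close to those of compound 1 and compound 3, and the difference between the core of compound 2 and the core of compound 3 is not broken down here.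

Compound 4 `Cc1ccc(/C=C2\CN(C(=S)SCc3cn(Cc4ccccc4Cl)nn3)C/C(=C\c3ccc(C)cc3)C2=O)cc1` carries the same kind of change, (chloro in place of fluoro on an aromatic carbon), on the same place of the benzyl ring. Because the earlier step of a 1.7-fold higher number from compound 3 to compound 1 (0.24 log units; within the scatter) stayed within the scatter, the step of a 1.2-fold higher number from compound 2 to compound 4 (0.08 log units; within the scatter) is expected to be small as well, so compound 4 is estimated to give about 110000 nM in this assay, likely between 60000 nM and 200000 nM.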

Compound 4, half-maximal inhibitory concentration: 93200 nM
Estimate against measurement, compound 4: 1.2-fold (0.07 log units) above; the range from low to high includes it.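

In this assay, replacing the 2-fluorobenzyl group with a 2-chlorobenzyl group on the core of compound 2 gives a 1.0-fold higher number from compound 2 to compound 4 (0.01 log units; within the scatter). Set beside the same change on the core of compound 3, the two results do not differ by more than the measurements can resolve: the same change on two cores in this assay, a 1.7-fold higher number (0.24 log units; within the scatter) from compound 3 to compound 1 and a 1.0-fold higher number (0.01 log units; within the scatter) from compound 2 to compound 4, 1.7-fold (0.23 log units) apart, within the scatter of two such steps. This shows that on these two cores the change from fluoro to chloro gave no step beyond the scatter, but it does not show that the change has no effect at all, since a small real effect could be hidden in that scatter, and two cores are too few to set a rule for the whole series.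

The compounds shown leave open what other groups on the benzyl ring would do in place of fluoro or chloro, such as a methoxy group, a nitrile, an amine or a carboxylic acid. On these data alone, it also remains open whether the change from fluoro to chloro would stay this small on a core with different aryl arms.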